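Thiophen-3-yl in place of 4-fluorophenyl: a small step expected

The source may hold more compounds than are shown below. What is called first, only, known or untested is meant among the compounds shown, and "the series" means these compounds.

Of the compounds shown here, three sharing one core have been measured in a functional assay on MCF7 cells (Homo sapiens) for antiproliferative activity, read by MTT assay, with a stated time of 48 h; on this read-out higher numbers stand for weaker inhibition and lower numbers for stronger inhibition. Compound 1 `CC(=O)N1N=C(c2ccc3ccccc3c2)OC1c1ccccc1Br` gives 5.49 ug/mL, compound 2 `CC(=O)N1N=C(c2ccc3ccccc3c2)OC1c1ccc(F)cc1` gives 3.02 ug/mL and compound 3 `CC(=O)N1N=C(c2ccc3ccccc3c2)OC1c1ccc2ccccc2c1` gives 1.01 ug/mL. Compound 2 therefore sits within the scatter of compound 1, while the number of compound 3 lies lower than that of compound 2 by more than the scatter.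

The unmeasured compound 4 `CC(=O)N1N=C(c2ccc3ccccc3c2)OC1c1ccsc1` keeps the shared core and carries thiophen-3-yl in place of 4-fluorophenyl on a saturated ring carbon. Among the compounds with values here, the one measured step at this carbon is a 1.8-fold lower number from compound 1 to compound 2 (0.26 log units; within the scatter), so exchanging those two groups did not move the number beyond the scatter. Compound 3, at 1.01 ug/mL, shows that a lower number is possible with another group on this carbon. Within the data shown here, no compound with a five-membered aromatic ring there has been measured, so the data give no direction for this change. No step beyond the scatter is therefore expected in this assay, and the expected change is a 1.1-fold higher number from compound 2 to compound 4 (0.03 log units; within the scatter). For compound 4 the estimated value is 3.2 ug/mL, with an expected range from 1.3 ug/mL to 7.5 ug/mL.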

Compound 4, half-maximal inhibitory concentration: 7.98 ug/mL
The estimate for compound 4 lay 2.5-fold (0.40 log units) below the measured number, outside the stated range (above it).
By their numbers in this assay, from the lowest: compound 3; then compounds 2, 1 and 4 (each within the scatter of the next, the first and the last beyond it).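

In this assay, within the data shown here, the exchange of 4-fluorophenyl for thiophen-3-yl on the saturated ring carbon gives a 2.6-fold higher number from compound 2 to compound 4 (0.42 log units; beyond the scatter) and so moves the number beyond the scatter, which the one earlier step at this carbon did not do. Thiophen-3-yl and 2-bromophenyl, by contrast, stay close, with a 1.5-fold higher number from compound 1 to compound 4 (0.16 log units; within the scatter) in this assay, so these two groups cannot be told apart here even though one is a five-membered aromatic ring and the other a six-membered one. This carbon now spans compound 3 at 1.01 ug/mL and compound 4 at 7.98 ug/mL on the same shared core, a gap beyond the scatter, although no measurement at hand offers a reason for the step from compound 2.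

The step from compound 2 changes the ring size, brings in a sulfur and removes the fluorine all at once, and the compounds shown do not separate these changes; an unsubstituted phenyl or a furan-3-yl would bear on that question. All four groups on this carbon are aromatic rings, so the compounds shown also leave open how an amine or a carboxylic acid there would read in this assay.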